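The compounds below may be only part of what the source reports. "The series", "measured", "known", "first", "only" and "open" are said of these compounds alone.

Compound 2 `O=C(O)CCCNC(=O)[C@]1(O)C[C@@H](O)[C@@H](O)[C@H](O)C1` was tested in an assay on HL-60 cells for inhibition of E-selectin (Homo sapiens), tested at 50 mM (on this read-out lower numbers stand for less inhibition and higher numbers for more inhibition at the one concentration tested (going by the name of the read-out)), where compound 2 gives 40%. Compound 1 `O=C(O)CNC(=O)[C@]1(O)C[C@@H](O)[C@@H](O)[C@H](O)C1` in this assay gives 38%, and the two numbers lie within the scatter of each other. Compound 3 `O=C(O)CCCCCNC(=O)[C@]1(O)C[C@@H](O)[C@@H](O)[C@H](O)C1` has not yet been measured. It differs from compound 2 by 2-carboxyethyl in place of carboxy on a saturated chain carbon, three bonds along the chain from an amide-type nitrogen. Going by the values given here, the only measured step that bears on this change, a number 2 percentage points higher from compound 1 to compound 2 (within the scatter), lengthened the same chain by the same group and stayed within the scatter. A step of similar size is therefore expected, a number 2 percentage points higher from compound 2 to compound 3 (within the scatter), with no direction beyond the scatter. Compound 3 is estimated at 42%, with a range from 28% to 56%.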

Compound 3, a percentage reported as inhibition, at one concentration (the size of the read-out at that concentration, not a potency): 31%
For compound 3 the middle estimate is 11 percentage points above the measured one; the range from low to high includes it.
By their numbers in this assay, from the lowest: compounds 3, 1 and 2 (each within the scatter of the next).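

In this assay, 2-carboxyethyl in place of carboxy three bonds along the chain from an amide-type nitrogen gives a number 9 percentage points lower from compound 2 to compound 3 (within the scatter), and 4-carboxybutyl in place of carboxy on the saturated chain carbon bound to that nitrogen gives a number 7 percentage points lower from compound 1 to compound 3 (within the scatter). A second lengthening therefore separates these compounds no more than the first did, and the three chain lengths cannot be ranked on this read-out. No evidence here accounts for these numbers. On these data alone, whether a longer chain, or an amine in place of the carboxylic acid, would give a step beyond the scatter remains open.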